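A Nitro Group Rearranged: From Compound 2 to Compound 3

The source may hold more compounds than are shown below. What is called first, only, known or untested is meant among the compounds shown, and "the series" means these compounds.

Going by the values given here, compound 2 `O=C1NC(=O)/C(=C/c2ccc(OCCSc3nnc(-c4ccc([N+](=O)[O-])cc4)[nH]3)cc2)S1` holds the lower of the two numbers measured so far in a functional assay on the whole organism (strain Wistar) with Rattus norvegicus as the target, with a stated time of 15 days, at a dose of 100 mg/kg by the oral route (on this read-out lower numbers stand for a weaker effect and higher numbers for a stronger effect at the one dose given), where compound 2 gives 22.1%. Compound 1 `O=C1NC(=O)/C(=C/c2ccc(OCCSc3nnc(-c4ccccc4)[nH]3)cc2)S1` carries hydrogen where the nitro group sits in the other measured compound; in this assay compound 1 gives 38.9%, and the step of a number 16.8 percentage points lower from compound 1 to compound 2 (beyond the scatter) is the only one recorded. Compound 3 `O=C1NC(=O)/C(=C/c2ccc(OCCSc3nnc(-c4ccccc4[N+](=O)[O-])[nH]3)cc2)S1` has not yet been measured; it is built from the same atoms as compound 2, joined differently, the change being (2-nitrophenyl in place of 4-nitrophenyl on an aromatic carbon).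

Among the compounds with values here, the single measured step concerns adding a nitro group, not rearranging it, so it bears on compound 3 only loosely: it shows that compounds bearing a nitro group on this ring sit in the weaker part of the small range seen so far. Within the data shown here, no measured pair shows what a rearranged nitro group does. Compound 3 is therefore expected to stay close to compound 2, with a step of a number 4.9 percentage points higher from compound 2 to compound 3 (within the scatter) that lies within the usual scatter. In this assay compound 3 is estimated at 27%, expected to fall between 12% and 45%.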

Compound 3, a percentage reported as activity, at one dose (the size of the read-out at that dose, not a potency): 49.1%
The estimate for compound 3 lay 22.1 percentage points below the measured number; measured number outside the range, above it.
By their numbers in this assay, from the lowest: compound 2; then compound 1; then compound 3.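

Where the nitro group stands on the phenyl ring matters in this assay: replacing 4-nitrophenyl with 2-nitrophenyl gives a number 27 percentage points higher from compound 2 to compound 3 (beyond the scatter) even though the atoms stay the same. The earlier step, a number 16.8 percentage points lower from compound 1 to compound 2 (beyond the scatter), had tied the nitro group to a lower number, but that holds only for 4-nitrophenyl, since the comparison with the plain phenyl of compound 1 now gives a number 10.2 percentage points higher from compound 1 to compound 3 (beyond the scatter) and so runs the other way. No measurement shown here explains why the two nitrophenyl groups part so widely.

Going by these compounds, it remains open whether the higher number belongs to the nitro group itself or would persist with an amine, a carboxylic acid or a methoxy group in its place on the ring of compound 3. Also open, on these data alone, is whether the gap between the two nitrophenyl groups would survive a longer chain in place of the link within the shared core, and whether it would hold at other doses, as each number here reports the size of the effect at one dose, not a potency.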